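Chain lengthening in a bis-indolyl hydroxamate pair

The source may hold more compounds than are shown below. What is called first, only, known or untested is meant among the compounds shown, and "the series" means these compounds.

compound 1 `O=C(CCCC(c1c[nH]c2ccccc12)c1c[nH]c2ccccc12)NO` — > 20000 nM
compound 2 `O=C(CCCCC(c1c[nH]c2ccccc12)c1c[nH]c2ccccc12)NO` — 5800 nM
compound 3 `O=C(CCCCCCC(c1c[nH]c2ccccc12)c1c[nH]c2ccccc12)NO` — not yet measured

In a functional assay on HCT-116 cells (Homo sapiens) for cytotoxicity, read by sulforhodamine B assay, with a stated time of 24 h (a higher number here means a weaker inhibitor, a lower number a stronger inhibitor), compound 1 sits at the limit of > 20000 nM in this assay, at which 1 of the 2 values shown sits, so its value > 20000 nM is a limit and not a number. In this assay compound 2 gives 5800 nM. For compound 2 this is the only number shown; the one other value in the set is a limit. Within the data shown here, the single measured step is an at least 3.4-fold lower number from compound 1 to compound 2 (0.53 log units; beyond the scatter), a lowering on lengthening the chain by one carbon.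

Compound 3 differs from compound 2 by 2-(hydroxycarbamoyl)ethyl in place of hydroxycarbamoyl on a saturated chain carbon, five bonds along the chain from two aromatic carbons. Among the measured compounds shown here, the only step that bears on this change is an at least 3.4-fold lower number from compound 1 to compound 2 (0.53 log units; beyond the scatter), the same kind of lengthening, and it was at least modest in the lowering direction. A further lowering is therefore expected, of modest size, though how far the trend carries beyond compound 2 is not shown. Compound 3 is expected at 2200 nM, within 600 nM to 8000 nM, an estimated step of a 2.6-fold lower number from compound 2 to compound 3 (0.42 log units; beyond the scatter).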

Compound 3, half-maximal inhibitory concentration: 3500 nM
Compound 3: middle estimate off by 1.6-fold (0.20 log units), on the low side, and the stated range covers the measured number.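

In this assay, the change to 2-(hydroxycarbamoyl)ethyl on the saturated chain carbon gives a 1.7-fold lower number from compound 2 to compound 3 (0.22 log units; within the scatter), so compound 2 and compound 3 cannot be told apart and this further lengthening adds no clear effect. Against the shortest chain, 3-(hydroxycarbamoyl)propyl in place of hydroxycarbamoyl still reads an at least 5.7-fold lower number from compound 1 to compound 3 (0.75 log units; beyond the scatter), so among these three compounds the only clear separation is from the shortest chain. The value of compound 1 is a limit and not a number: the limit of > 20000 nM in this assay, at which 1 of the 3 values shown sits.

Open, as far as these compounds go, is whether a chain longer than that of compound 3 would move the number beyond the scatter or leave it level. Also open, from the compounds shown here alone, is whether a carboxylic acid or a primary amide in place of hydroxycarbamoyl at the chain end would keep any of this cytotoxicity.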